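The source may report more compounds than this note shows. Statements on the series, on what has been measured and on what is new or still open speak of the compounds shown alone.

Measured so far:
Compound 1 `CC(C)NC(=O)CC(c1ccc(-c2ccc3cccc(F)c3c2)[nH]c1=O)C(C)C` — 0.32 h
Compound 2 `CC(C)[C@H](C[C@H]1CCNC1=O)c1ccc(-c2ccc3cccc(F)c3c2)[nH]c1=O` — 0.257 h

In an ADME assay on microsomes from liver (Homo sapiens) for metabolic stability (on this read-out lower numbers stand for a shorter-lived compound and higher numbers for a longer-lived compound), compound 1 gives 0.32 h, the higher of the two numbers, while compound 2 gives 0.257 h; the gap between them lies within the scatter, so neither stands apart from the other in this assay. Compound 3 `CC(C)C(c1ccc(-c2ccc3cccc(F)c3c2)[nH]c1=O)N1CCNC1=O` is not yet measured. It differs from compound 1 in one place: 2-oxoimidazolidin-1-yl in place of (isopropylcarbamoyl)methyl on a saturated chain carbon bound to an aromatic carbon and a saturated chain carbon. For the measured compounds named here, with no step between measured compounds to draw on, the change is expected to move the number by no more than the scatter, in either direction, so the step of a 1.1-fold lower number from compound 1 to compound 3 (0.03 log units; within the scatter) is an expectation only. For compound 3 the estimate is 0.3 h, within 0.12 h to 0.75 h.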

Compound 3, half-life: 1.03 h
For compound 3 the middle estimate is 3.4-fold (0.54 log units) below the measured one; the whole stated range lies below it.
By their numbers in this assay, from the lowest: compounds 2 and 1 (each within the scatter of the next); then compound 3.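

In this assay, this saturated chain carbon, bound to an aromatic carbon and a saturated chain carbon, proves sensitive to its substituent: 2-oxoimidazolidin-1-yl in place of (isopropylcarbamoyl)methyl gives a 3.2-fold higher number from compound 1 to compound 3 (0.51 log units; beyond the scatter), the first step available in this series. The two groups share the same printed counts of hydrogen-bond donors and acceptors, but only the entering group contains a ring. No available evidence accounts for the step.

Going by these compounds, it remains open whether the ring itself matters, as a single change cannot separate it from the other differences between the groups. An open-chain urea or a six-membered cyclic urea at this carbon would test that question.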